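Moving the Methyl Around the Outer Ring

The compounds below may be only part of what the source reports. "The series", "measured", "known", "first", "only" and "open" are said of these compounds alone.

Three measured compounds share one core and differ only in the group on an oxygen on an aromatic ring. Compound 1 `N[C@@H](COP(=O)(O)OCCCOC(=O)CCc1ccccc1OCc1cccc(OC2CCCCC2)c1)C(=O)O` gives 18.8% in an assay on cells for agonist activity at probable G-protein coupled receptor 34 (Mus musculus), with a stated time of 1 h; a higher number here means a larger maximal response, a lower number a smaller maximal response. Compound 2 `Cc1ccccc1Oc1cccc(COc2ccccc2CCC(=O)OCCCOP(=O)(O)OC[C@H](N)C(=O)O)c1` gives 20.3%, and compound 3 `Cc1cccc(Oc2cccc(COc3ccccc3CCC(=O)OCCCOP(=O)(O)OC[C@H](N)C(=O)O)c2)c1` gives 21.3%, the highest number of the three, though the gap a number 2.5 percentage points higher from compound 1 to compound 3 (within the scatter) is within the scatter. Compound 4 `Cc1ccc(Oc2cccc(COc3ccccc3CCC(=O)OCCCOP(=O)(O)OC[C@H](N)C(=O)O)c2)cc1` differs from compound 3 by 4-methylphenyl in place of 3-methylphenyl on an oxygen on an aromatic ring. For the measured compounds named here, the one earlier step that moved the methyl, a number 1 percentage points higher from compound 2 to compound 3 (within the scatter), stayed within the scatter, as did the step of a number 1.5 percentage points higher from compound 1 to compound 2 (within the scatter), so the expected step of a number 0.3 percentage points lower from compound 3 to compound 4 (within the scatter) is none beyond the scatter. Compound 4 is therefore estimated at 21%, with a range from 13% to 29%.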

Compound 4, largest response reached (Emax), in percent of the reference or control that the assay uses: 18.2%
The estimate for compound 4 lay 2.8 percentage points above the measured number, within the range that was stated.
By their numbers in this assay, from the lowest: compounds 4, 1, 2 and 3 (each within the scatter of the next).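

With 4-methylphenyl on this oxygen, all three methylphenyl groups can be compared in this assay and none stands apart, with steps of a number 3.1 percentage points lower from compound 3 to compound 4 (within the scatter) and a number 2.1 percentage points lower from compound 2 to compound 4 (within the scatter) in this set. Even the step of a number 0.6 percentage points lower from compound 1 to compound 4 (within the scatter) from cyclohexyl stays small, so neither the place of the methyl nor the choice between these ring groups separates the compounds here. Nothing measured here bears on this flat result. Still open, from the compounds shown here alone, is whether a phenyl ring carrying an amine or a carboxylic acid in place of the methyl would give a step beyond the scatter.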